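One Amide Side Group Exchanged in a Cell Test

The source may report more compounds than this note shows. Statements on the series, on what has been measured and on what is new or still open speak of the compounds shown alone.

Results so far in a functional assay on MCF7 cells (Homo sapiens) for cytotoxicity, read by MTT assay, with a stated time of 72 h (on this read-out higher numbers stand for weaker inhibition and lower numbers for stronger inhibition), are these:
- compound 1 `N[C@H]1CC[C@H](Nc2c(C(=O)NCc3ccc(Cl)cc3)nc(Br)c3cccnc23)CC1` with "not determined" (no result reported) as its result
- compound 2 `N[C@H]1CC[C@H](Nc2c(C(=O)NCc3ccccn3)nc(Br)c3cccnc23)CC1` with 15000 nM as its result

Within the data shown here, compound 2 holds the only number so far, so it cannot yet be ranked against another compound. Compound 1 offers no comparison, as it has no numerical result.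

The next compound to be tested is compound 3 `N[C@H]1CC[C@H](Nc2c(C(=O)NCc3cccc(C(F)(F)F)c3)nc(Br)c3cccnc23)CC1`, which keeps the core of compound 2 and differs in one place. The difference, (3-(trifluoromethyl)phenyl in place of pyridin-2-yl on a saturated chain carbon bound to an amide-type nitrogen), is 3-(trifluoromethyl)phenyl in place of pyridin-2-yl on a saturated chain carbon bound to an amide-type nitrogen.

Among the measured compounds shown here, no measured pair yet shows what this exchange does in this assay, so any forecast is tentative. Taking compound 2 at 15000 nM as the sole anchor, a moderate move toward lower numbers, meaning stronger inhibition, seems the likelier outcome, though a result within the usual scatter would be no surprise. The estimated change is a 2.1-fold lower number from compound 2 to compound 3 (0.33 log units; beyond the scatter) in this forecast. For compound 3 the expected value is 7000 nM, with an estimated range from 2000 nM to 25000 nM as its bounds.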

Compound 3, half-maximal inhibitory concentration: 15000 nM
The estimate for compound 3 lay 2.1-fold (0.33 log units) below the measured number; the range from low to high includes it.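

In this assay, placing 3-(trifluoromethyl)phenyl in place of pyridin-2-yl on a saturated chain carbon bound to an amide-type nitrogen gives no change at the digits printed from compound 2 to compound 3 (within the scatter). Among these compounds, this is the first comparison that can be read at this position, and it shows that a carbon-only aromatic ring with more heavy atoms and no hydrogen-bond acceptor can replace a ring containing nitrogen and one acceptor without a detectable difference in this cell test. No available measurement accounts for the two compounds reading alike.

The effect of the chlorine-bearing benzyl group cannot be read, since compound 1 gives "not determined" (no result reported) in this assay. As far as these compounds go, two aromatic groups at this place do not define what other kinds of group would do, so it remains open whether a carboxylic acid, an amine or a longer chain between the amide nitrogen and the ring would give a number that differs from those of compound 2 and compound 3.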